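Shared core series: carbamoyl in place of hydroxyl on cyclohexyl

The source may hold more compounds than are shown below. What is called first, only, known or untested is meant among the compounds shown, and "the series" means these compounds.

Measured so far:
compound 1, `N#Cc1cnc(NCc2cnccc2C(F)(F)F)cc1N[C@H]1CC[C@H](O)CC1`, 6500 nM
compound 2, `N#Cc1cnc(NCc2ccccc2C(F)(F)F)cc1N[C@H]1CC[C@H](O)CC1`, > 10000 nM
compound 3, `N#Cc1cnc(NCc2cnccc2C(F)(F)F)cc1NCC1CCOCC1`, 5000 nM
compound 4, `N#Cc1cnc(NCc2cnccc2C(F)(F)F)cc1N[C@H]1CC[C@@H](C(N)=O)CC1`, not yet measured

In an assay on isolated protein for inhibition of protein kinase C delta type (Homo sapiens), read by TR-FRET, with a stated time of 2 h (on this read-out lower numbers stand for stronger inhibition and higher numbers for weaker inhibition), compound 1 gives 6500 nM, the highest of the two numbers shown. The nearest number is that of compound 3: a 1.3-fold lower number from compound 1 to compound 3 (0.11 log units; within the scatter), so the two stand together. Compound 2 sits at the limit of > 10000 nM in this assay, at which 1 of the 3 values shown sits, which is a limit of the assay and not a number.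

The step to compound 4 is 4-carbamoylcyclohexyl in place of 4-hydroxycyclohexyl on a nitrogen on an aromatic ring. Among the compounds with values here, no measured step touches the 4-carbamoylcyclohexyl group. Within the data shown here, the only measured step that alters the same position, from compound 1 to compound 3, exchanges the whole 4-hydroxycyclohexyl for (oxan-4-yl)methyl and stays within the scatter, which suggests that this position tolerates change without a large move in the read-out. On that basis no step beyond the scatter is expected for compound 4 in this assay, in either direction, and the uncertainty is wide. Compound 4 is estimated at 6000 nM, with a range from 2000 nM to 18000 nM, which means an expected step of a 1.1-fold lower number from compound 1 to compound 4 (0.03 log units; within the scatter).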

Compound 4, half-maximal inhibitory concentration: 400 nM
The estimate for compound 4 lay 15-fold (1.18 log units) above the measured number, outside the stated range (below it).
By their numbers in this assay, from the lowest: compound 4; then compounds 3 and 1 (each within the scatter of the next). At a limit, above all of these: compound 2.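

In this assay the step of a 16-fold lower number from compound 1 to compound 4 (1.21 log units; beyond the scatter) and the step of a 13-fold lower number from compound 3 to compound 4 (1.10 log units; beyond the scatter) show that the group on a nitrogen on an aromatic ring can move this read-out by a large amount, which the earlier pair at this place did not show. The earlier step of a 1.3-fold lower number from compound 1 to compound 3 (0.11 log units; within the scatter) stays within the scatter, so the tolerance seen at this place holds between 4-hydroxycyclohexyl and (oxan-4-yl)methyl but does not extend to 4-carbamoylcyclohexyl. Of the three groups compared on this core, 4-carbamoylcyclohexyl alone stands apart from the other two, and those two hold no order between them.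

It remains open which part of the carbamoyl group carries the step: an N-methylcarbamoyl, a carboxylic acid, an aminomethyl or a longer chain ending in carbamoyl on the same cyclohexyl would separate the carbonyl from the amide hydrogen, and the opposite stereoisomer of compound 4 and the same group on the core of compound 2 are also absent from the compounds shown. Nothing in the data shown gives a measured reason for the size of these steps.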